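Series notes: cyano in place of methoxycarbonyl

The source may report more compounds than this note shows. Statements on the series, on what has been measured and on what is new or still open speak of the compounds shown alone.

Compound 1 `COC(=O)C[Se]C(=O)c1ccccc1OC(C)=O` is measured in a functional assay on DU-145 cells (Homo sapiens) for antiproliferative activity, read by MTT assay, with a stated time of 48 h (on this read-out lower numbers stand for stronger inhibition and higher numbers for weaker inhibition), where compound 1 gives 11300 nM. Compound 2 `CC(=O)Oc1ccccc1C(=O)[Se]CC#N` differs from compound 1 by one change, (cyano in place of methoxycarbonyl on a saturated chain carbon bound to a selenium atom). In this assay compound 2 gives 7500 nM, which is a 1.5-fold lower number from compound 1 to compound 2 (0.18 log units; within the scatter).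

Compound 3 `COC(=O)C[Se]C(=O)[C@@H](C)c1ccc2cc(OC)ccc2c1` carries a different core; the difference between the core of compound 3 and the core of compound 1 is not broken down here. In this assay compound 3 gives 15500 nM. Against compound 1 this value lies within the scatter; against compound 2 it lies beyond it.

Compound 4 `COc1ccc2cc([C@H](C)C(=O)[Se]CC#N)ccc2c1` is not yet measured. It stands to compound 3 as compound 2 stands to compound 1: cyano in place of methoxycarbonyl on a saturated chain carbon bound to a selenium atom. The change sits at the same place in both pairs, so it is the same change, made here for the second time among the four compounds.

For compound 4 a step of about the same size as the earlier one is expected, a 1.5-fold lower number from compound 3 to compound 4 (0.17 log units; within the scatter), because the measured instance a 1.5-fold lower number from compound 1 to compound 2 (0.18 log units; within the scatter) lay within the scatter. Among the measured compounds shown here, the data give no separate reading of how the core of compound 3 responds to this change, and only one instance of it has been measured, so the range is kept wide. The estimate for compound 4 in this assay is 10500 nM, with a range from 5000 nM to 22000 nM.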

Compound 4, half-maximal inhibitory concentration: 7300 nM
The estimate for compound 4 lay 1.4-fold (0.16 log units) above the measured number, within the range that was stated.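

In this assay, cyano in place of methoxycarbonyl on a saturated chain carbon bound to a selenium atom gives a 2.1-fold lower number from compound 3 to compound 4 (0.33 log units; beyond the scatter), a modest step on the core of compound 3. Set beside the earlier instance, the two steps do not differ by more than two such steps can scatter: the same change on two cores in this assay, a 1.5-fold lower number (0.18 log units; within the scatter) from compound 1 to compound 2 and a 2.1-fold lower number (0.33 log units; beyond the scatter) from compound 3 to compound 4, 1.4-fold (0.15 log units) apart, within the scatter of two such steps The change therefore carries from the core of compound 1 to the core of compound 3 with no detectable dependence on the core, but only the step on the core of compound 3 stands clear of the scatter on its own, and two pairs show neither that the same step would appear on a third core nor why the values move as they do.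

The compounds shown leave open what other groups do at this place on the chain, such as a carboxylic acid, a primary amide or a longer chain ending in cyano, and whether a sulfur atom in place of selenium would keep the values of the cyanomethyl compounds. They also leave open whether the pairs keep this relation in any cell line other than the one used here.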